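Trifluoromethyl to methyl on the shared core

The source may report more compounds than this note shows. Statements on the series, on what has been measured and on what is new or still open speak of the compounds shown alone.

Measured in a functional assay on A549 cells (Homo sapiens) for antiproliferative activity, read by MTT assay, with a stated time of 48 h; on this read-out lower numbers stand for stronger inhibition and higher numbers for weaker inhibition:
- compound 1 `COc1ccc(-c2nn(-c3ccccc3)cc2-c2nc3cc(F)ccc3[nH]2)cc1`: 1980 nM
- compound 2 `COc1ccc(-c2nn(-c3ccccc3)cc2-c2nc3cc(C(F)(F)F)ccc3[nH]2)cc1`: 4820 nM

Compound 2 holds the higher of the two numbers in this assay, at 4820 nM. The next analogue is compound 3 `COc1ccc(-c2nn(-c3ccccc3)cc2-c2nc3cc(C)ccc3[nH]2)cc1`, with methyl in place of trifluoromethyl on an aromatic carbon.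

Going by the values given here, one measured step bears on this change, and it involves the same aromatic carbon: a 2.4-fold higher number from compound 1 to compound 2 (0.39 log units; beyond the scatter). Among the compounds with values here, no methyl analogue has a value yet, so the expectation rests on this single pair. Leaving trifluoromethyl is expected to give a modest move toward lower numbers in this assay, possibly not beyond the scatter. The expected step is a 1.6-fold lower number from compound 2 to compound 3 (0.21 log units; within the scatter). The estimate for compound 3 is 3000 nM, with an expected range of 1300 nM to 6500 nM.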

Compound 3, half-maximal inhibitory concentration: 5070 nM
Compound 3: the middle estimate sits 1.7-fold (0.23 log units) below what was measured; the range from low to high includes it.
By their numbers in this assay, from the lowest: compound 1; then compounds 2 and 3 (each within the scatter of the next).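

In this assay, the change from trifluoromethyl to methyl on this aromatic carbon gives a 1.1-fold higher number from compound 2 to compound 3 (0.02 log units; within the scatter) and so does not separate the two groups, although trifluoromethyl has 4 heavy atoms and methyl has 1. Fluoro now stands apart from both groups at this position, as methyl in its place gives a 2.6-fold higher number from compound 1 to compound 3 (0.41 log units; beyond the scatter) and trifluoromethyl gives a 2.4-fold higher number from compound 1 to compound 2 (0.39 log units; beyond the scatter) on the same core. Nothing available here explains why fluoro differs from the other two groups.

Going by these compounds alone, it remains open whether any group on this carbon can reach a lower number than compound 1 does, since only three groups are compared here. As far as these compounds go, it is also open how the core responds to an amine, a hydroxyl group or a carboxylic acid at this position.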